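A few compounds are considered here, and "the series" means these few. Any claim that something is new, unique, unknown or untested is made for them only; others in the source may bear on it.

In a functional assay on DU-145 cells (Homo sapiens) for inhibition, read by trypan blue exclusion, with a stated time of 96 h (a lower number here means a stronger inhibitor of growth, a higher number a weaker inhibitor of growth), compound 1 (`Cc1ccc(C)c(/C=C(\C(=O)c2ccc(Cl)cc2)S(=O)(=O)c2ccc(Br)cc2)c1`) gives 1000 nM and compound 2 (`Cc1ccc(CS(=O)(=O)/C(=C/c2ccc(N(C)C)cc2)C(=O)c2ccc(Cl)cc2)cc1`) gives 50000 nM as the higher of the two numbers, a gap beyond the scatter that makes it the weaker inhibitor of growth of the pair. Compound 3 (`CN(C)c1ccc(/C=C(\C(=O)c2ccc(Cl)cc2)S(=O)(=O)c2ccc(Br)cc2)cc1`) departs from compound 2 in one place, with 4-bromophenyl in place of 4-methylbenzyl on a sulfonyl sulfur. Within the data shown here, no step between measured compounds isolates this change. Among the measured compounds shown here, compound 1 also carries 4-bromophenyl on its sulfonyl sulfur and gives 1000 nM as the only guide, but it differs from compound 3 elsewhere, so only part of the gap is expected to carry over. The expected change is an 8.3-fold lower number from compound 2 to compound 3 (0.92 log units; beyond the scatter) toward a lower number, beyond the scatter. For compound 3 the estimated value is 6000 nM with an expected range of 1000 nM to 30000 nM in the same measurement.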

Compound 3, concentration for 50% growth inhibition: > 100000 nM
Compound 3: only a limit was reported (the forecaster's own chance of this, stated with the estimate: 5%); at least 16-fold (1.22 log units) between middle value and limit.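

In this assay compound 3 stands only at a limit, and how far past it the compound lies cannot be told: the limit of > 100000 nM in this assay, at which 1 of the 3 values shown sits. Putting 4-bromophenyl in place of 4-methylbenzyl on a sulfonyl sulfur gives an at least 2.0-fold higher number from compound 2 to compound 3 (0.30 log units; that floor lies within the scatter), so this change at this position brought no lower number with 4-(dimethylamino)phenyl on the double-bonded chain carbon, and its true size stays unresolved. With 4-bromophenyl kept on the sulfonyl sulfur, the change on the double-bonded chain carbon gives an at least 100-fold higher number from compound 1 to compound 3 (2.00 log units; beyond the scatter), which shows that the 4-bromophenyl group did not secure a low number by itself.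

The compounds shown leave open how 4-methylbenzyl on the sulfonyl sulfur would read with 2,5-dimethylphenyl on the double-bonded chain carbon. They also leave open whether 4-methoxyphenyl or 4-carboxyphenyl on that carbon would behave like 4-(dimethylamino)phenyl.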